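The source may report more compounds than this note shows. Statements on the series, on what has been measured and on what is new or still open speak of the compounds shown alone.

Measured compounds:
Compound 1 `O=C(NO)c1ccc(Cn2nnc(-c3ccccn3)n2)cc1` — in an assay on Sf9 cells for inhibition of protein deacetylase HDAC6 (Homo sapiens), read by fluorescence (on this read-out lower numbers stand for stronger inhibition and higher numbers for weaker inhibition), compound 1 gives 9 nM.
Compound 2 `O=C(NO)c1ccc(Cc2nnc(-c3ccccc3)o2)cc1` — compound 2 gives 4 nM.
Compound 3 `Cc1cc(-c2nnc(Sc3c(F)c(F)c(C(=O)NO)c(F)c3F)n2C)nn1C` — compound 3 gives 2530 nM.

Among these three numbers compound 1 stands second highest. Compound 2 lies nearest to it, with a lower number beyond the scatter, while compound 3 lies far away with a much higher number. Compound 4 `O=C(NO)c1ccc(Cn2nnc(-c3ccccc3)n2)cc1` has not yet been tested. It differs from compound 1 in a single place: phenyl in place of pyridin-2-yl on an aromatic carbon. Since compound 2, which also carries a phenyl on its five-membered ring, gives 4 nM, the change is not expected to move the number far in either direction. The step of a 1.3-fold lower number from compound 1 to compound 4 (0.11 log units; within the scatter) is expected to stay within the scatter. Compound 4 is therefore estimated at 7 nM, within a range from 3 nM to 16 nM.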

Compound 4, half-maximal inhibitory concentration: 3 nM
For compound 4 the middle estimate is 2.3-fold (0.37 log units) above the measured one; the measured number falls inside the stated range.
By their numbers in this assay, from the lowest: compounds 4 and 2 (each within the scatter of the next); then compound 1; then compound 3.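

In this assay, phenyl in place of pyridin-2-yl on the aromatic carbon of the five-membered ring gives a 3.0-fold lower number from compound 1 to compound 4 (0.48 log units; beyond the scatter), a modest step and the first here that isolates a single change. It shows that the ring nitrogen of pyridin-2-yl is not required for a low number at this position, and that the ring of carbon only gives the lower number on this core. Nothing at hand explains the direction of this step.

On these data alone, whether an amine or a carboxylic acid on the phenyl would keep the number this low remains open. So does whether the same change would give a similar step on another core.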